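From a Propyl Chain to an Isopropoxyethyl Chain

A few compounds are considered here, and "the series" means these few. Any claim that something is new, unique, unknown or untested is made for them only; others in the source may bear on it.

Compound 1: `Nc1nc(Cl)c(-c2ccccn2)c(N[C@@H]2C[C@H](CO)[C@@H](O)[C@H]2O)n1` — > 25000 nM
Compound 2: `CCCNc1nc(C)c(-c2nc3ccccc3s2)c(N[C@@H]2C[C@H](CO)[C@@H](O)[C@H]2O)n1` — > 25000 nM

Of the compounds shown here, two have been measured in an ADME assay on cells (Homo sapiens) for cytotoxicity, read by polymerase chain reaction, with a stated time of 3 days; on this read-out higher numbers stand for lower toxicity in this test and lower numbers for higher toxicity in this test. Compound 1 gives > 25000 nM, which is a limit of the assay rather than a number. Compound 2 in turn gives > 25000 nM, again a limit of the assay and not a number. Within the data shown here, compound 2 therefore stands only at a limit, and the single other value shown is a limit as well, (the limit of > 25000 nM in this assay, at which 2 of the 2 values shown sit). Among the measured compounds shown here, compound 1 and compound 2 differ in more than one place, so no step between them can be read; all their two values show is that both sit at the same limit.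

Compound 3, `Cc1nc(NCCOC(C)C)nc(N[C@@H]2C[C@H](CO)[C@@H](O)[C@H]2O)c1-c1nc2ccccc2s1`, has not yet been measured in this assay. It differs from compound 2 in a single place: isopropoxy in place of methyl on a saturated chain carbon, two bonds along the chain from a nitrogen on an aromatic ring. With only two limits available, the expected step in this assay is none beyond the scatter, and this expectation is a step that the limit leaves unreadable from compound 2 to compound 3. Compound 3 is accordingly estimated at 30000 nM, with a range from 12000 nM to 80000 nM, and the assay is most likely to report a limit again.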

Compound 3, half-maximal cytotoxic concentration: 8000 nM
Estimate against measurement, compound 3: 3.8-fold (0.57 log units) above, outside the stated range (below it).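

In this assay, isopropoxy in place of methyl on a saturated chain carbon, two bonds along the chain from a nitrogen on an aromatic ring, gives an at least 3.1-fold lower number from compound 2 to compound 3 (0.49 log units; beyond the scatter). This shows that the end of this chain is not silent in this test: the change moves the read-out towards higher toxicity, and compound 3 is the first compound shown with a number rather than a limit. The true size of the step remains unknown, however, and the printed figure is only its smallest possible size, because compound 2 stands at a limit: the limit of > 25000 nM in this assay, at which 2 of the 3 values shown sit.

The compounds shown do not separate the oxygen of the isopropoxy group from the added chain length, so it remains open whether a plain longer chain of carbon atoms, such as butyl, would lower the number in the same way. As far as these compounds go, it is also open whether a smaller ether such as methoxy, or an amine or a carboxylic acid at the same place, would keep the number at the limit or lower it further.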